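The source may hold more compounds than are shown below. What is called first, only, known or untested is meant among the compounds shown, and "the series" means these compounds.

Of the compounds shown here, three of one shared core have been measured in a functional assay on the whole organism (artery, strain albino) with Rattus norvegicus as the target, with a stated time of 720 min, at a dose of 10 mg/kg by the oral route; a higher number here means more inhibition at the dose given (going by the name of the read-out), a lower number less inhibition. Compound 1 `CC1=C(C(=O)Nc2ccc(Br)cc2)C(c2ccc(Cl)cc2Cl)N=C(SCc2ccccc2)N1` gives 11.3% in this assay. Compound 2 `CC1=C(C(=O)Nc2ccc(Br)cc2)C(c2ccc(Cl)cc2Cl)N=C(SCc2ccccc2Cl)N1` gives 20.6%, and compound 3 `COc1ccc(C2N=C(SCc3ccccc3)NC(C)=C2C(=O)Nc2ccc(Br)cc2)cc1` gives 7.2%. Compound 3 sits close to compound 1, since a number 4.1 percentage points lower from compound 1 to compound 3 (within the scatter); against compound 2 it stands apart, with the value of compound 2 higher than that of compound 3 by more than the usual scatter.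

Compound 4 `COc1ccc(C2N=C(SCc3ccccc3Cl)NC(C)=C2C(=O)Nc2ccc(Br)cc2)cc1` is the next step from compound 3. The difference is chloro in place of hydrogen on an aromatic carbon. The same change was already seen once within these three compounds, from compound 1 to compound 2: a number 9.3 percentage points higher from compound 1 to compound 2 (within the scatter). Going by the values given here, that is the only measured step that bears on the present one, and it stayed within the scatter, so the data give no ground to expect anything larger here. The step from compound 1 to compound 3 changes a different part of the molecule and does not inform this move.

Compound 4 is therefore expected to lie near compound 3, with a step of about a number 6.8 percentage points higher from compound 3 to compound 4 (within the scatter) in this assay, a rise that would not count as a change. The estimate for compound 4 in this assay is 14%, with a range from 3% to 27%.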

Compound 4, a percentage reported as inhibition, in the whole organism at one dose (the size of the read-out at that dose, not a potency): 10.8%
The estimate for compound 4 lay 3.2 percentage points above the measured number; low and high end bracket the measured number.
By their numbers in this assay, from the lowest: compounds 3, 4, 1 and 2 (each within the scatter of the next, the first and the last beyond it).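

Chloro in place of hydrogen, on an aromatic carbon ortho to a large group, has now been read on a second core in this assay, where the benzylsulfanyl to (2-chlorobenzyl)sulfanyl change with the 4-methoxyphenyl group in place gives a number 3.6 percentage points higher from compound 3 to compound 4 (within the scatter). The change therefore stays inside the scatter on both cores, and the two readings agree with each other: the same change on two cores in this assay, a number 9.3 percentage points higher (within the scatter) from compound 1 to compound 2 and a number 3.6 percentage points higher (within the scatter) from compound 3 to compound 4, 5.7 percentage points apart, within the scatter of two such steps. The swap of 2,4-dichlorophenyl for 4-methoxyphenyl can now also be read with the 2-chlorobenzyl group present, as a number 9.8 percentage points lower from compound 2 to compound 4 (within the scatter), and it too stays small and consistent across the two cores: the same change on two cores in this assay, a number 4.1 percentage points lower (within the scatter) from compound 1 to compound 3 and a number 9.8 percentage points lower (within the scatter) from compound 2 to compound 4, 5.7 percentage points apart, within the scatter of two such steps.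

Going by these compounds alone, these four compounds show only that the two changes tested here, alone or on either core, produce no step beyond the scatter at this single oral dose and time, and they do not show whether chloro elsewhere on the benzyl ring would behave the same way. Also open, as far as these compounds go, is whether a more different group at the benzyl position, such as a carboxylic acid, an amine or a longer chain, would give a step that exceeds the scatter.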